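The compounds below may be only part of what the source reports. "The series", "measured", "known", "first", "only" and "open" are said of these compounds alone.

Measured compounds:
compound 1, `CO[C@@H]1O[C@H](COc2cccc(C(C)C)c2)[C@@H](O)[C@H](O)[C@H]1Oc1ccc(OC2CCCCC2)cc1`, 39000 nM
compound 2, `CO[C@H]1O[C@H](COc2ccc(OC3CCCCC3)cc2)[C@@H](O)[C@H](O)[C@H]1Oc1ccc(OC2CCCCC2)cc1`, 14000 nM
compound 3, `CO[C@@H]1O[C@H](COc2ccccc2C(C)C)[C@@H](O)[C@H](O)[C@H]1Oc1ccc(OC2CCCCC2)cc1`, 42000 nM

In a functional assay on HeLa cells (Homo sapiens) for cytotoxicity, read by MTT assay, with a stated time of 48 h (a lower number here means that less compound is needed, a higher number that more compound is needed for the effect), compound 2 stands lowest of the three measured compounds; compound 1 lies a 1.1-fold higher number from compound 1 to compound 3 (0.03 log units; within the scatter) apart from compound 3, and both sit well above compound 2, beyond the scatter. Compound 4, `CO[C@H]1O[C@H](COc2ccc(OC3CCCCC3)cc2)[C@@H](O)[C@H](O)[C@H]1Oc1ccc(C(C)C)cc1`, has not yet been measured. It differs from compound 2 by isopropyl in place of cyclohexyloxy on an aromatic carbon. Among the compounds with values here, no measured step bears directly on this exchange: the one step on record, from compound 1 to compound 3, moves an isopropylphenyl group on an oxygen on a saturated carbon and is within the scatter. What the values do show is that the two compounds carrying isopropylphenyl in place of cyclohexyloxyphenyl at that other position, compound 1 and compound 3, both give higher numbers than compound 2. Taken as a loose analogy, a similar exchange at the aromatic carbon is expected to push compound 4 upward as well, by a step of a 2.1-fold higher number from compound 2 to compound 4 (0.33 log units; beyond the scatter) in this assay, with wide uncertainty since the position and linkage differ. Compound 4 is therefore expected to give about 30000 nM in this assay, within 12000 nM to 80000 nM.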

Compound 4, half-maximal effective concentration: 18000 nM
For compound 4 the middle estimate is 1.7-fold (0.22 log units) above the measured one; the measured number falls inside the stated range.
By their numbers in this assay, from the lowest: compounds 2 and 4 (each within the scatter of the next); then compounds 1 and 3 (each within the scatter of the next).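

In this assay, within the data shown here, isopropyl in place of cyclohexyloxy on an aromatic carbon, para to a large group, gives a 1.3-fold higher number from compound 2 to compound 4 (0.11 log units; within the scatter), the first step on record at this position, and it lies within the scatter. The exchange removes the six-membered non-aromatic ring and the oxygen that links it, along with a hydrogen-bond acceptor, yet the assay does not separate compound 2 from compound 4, so neither that ring nor that oxygen is needed at this position to keep the number where compound 2 has it. No measurement on hand bears on why the two groups read alike here.

The compounds shown leave open whether this tolerance holds only for these two carbon-rich groups or extends to a group of another kind at the same place, such as an amine, a carboxylic acid or a longer alkyl chain. They also leave open whether isopropyl in place of the second cyclohexyloxy, on the other aromatic ring of compound 4, would read the same way.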